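Compound 1 to compound 4: a side-chain exchange

This account rests on a few compounds, and the source may have more. Where it says the series, first, only, none or still open, it means among the compounds named here.

In a physicochemical assay for solubility, measured as kinetic solubility, at pH 2 (a higher number here means a more soluble compound, a lower number a less soluble compound), compound 1 (`CC(C)C(CC1C(=O)NC(=O)N1C)c1ccc(-c2ccc3cccc(F)c3c2)[nH]c1=O`) gives 26600 nM. Compound 3 (`CCC(/C=C1\OC(=O)NC1=O)(CC)c1ccc(-c2ccc3cccc(F)c3c2)[nH]c1=O`) gives 13500 nM, within the scatter of compound 1. Compound 2 (`CC(C)[C@@H](c1ccc(-c2ccc3cccc(F)c3c2)[nH]c1=O)[C@@H]1OC(=O)NC1=O`) gives 6900 nM, lower than compound 1 by more than the scatter. Compound 4 (`CC(C)C(c1ccc(-c2ccc3cccc(F)c3c2)[nH]c1=O)C1SC(=O)NC1=O`) carries 2,4-dioxo-1,3-thiazolidin-5-yl in place of (3-methyl-2,5-dioxoimidazolidin-4-yl)methyl on a saturated chain carbon bound to an aromatic carbon and a saturated chain carbon. For the measured compounds named here, no measured pair isolates this exchange. A moderate fall beyond the scatter is expected in this assay, resting on compound 2 at 6900 nM, whose ring most resembles the entering group. The estimated change is a 3.3-fold lower number from compound 1 to compound 4 (0.52 log units; beyond the scatter). For compound 4 the expected value is 8000 nM, within an estimated range of 2500 nM to 25000 nM.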

Compound 4, solubility: 11300 nM
Compound 4: the middle estimate sits 1.4-fold (0.15 log units) below what was measured, and the stated range covers the measured number.
By their numbers in this assay, from the lowest: compounds 2, 4, 3 and 1 (each within the scatter of the next, the first and the last beyond it).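

In this assay, for the compounds shown here, the exchange of (3-methyl-2,5-dioxoimidazolidin-4-yl)methyl for 2,4-dioxo-1,3-thiazolidin-5-yl gives a 2.4-fold lower number from compound 1 to compound 4 (0.37 log units; beyond the scatter) and so provides the first step at this position that can be read in one place. It shows that this position on the saturated chain carbon tolerates the exchange with only a modest fall. Nothing available explains the step.

The step changes the ring and its attachment together, and the compounds shown do not separate the two. Going by these compounds, how a carboxylic acid or an amine at this position would read in this assay also remains open.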